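A Chloro Group Added to Compound 3

The source may report more compounds than this note shows. Statements on the series, on what has been measured and on what is new or still open speak of the compounds shown alone.

In a functional assay on NCI/ADR-RES cells (Homo sapiens) for inhibition, read by sulforhodamine B assay, with a stated time of 48 h (on this read-out lower numbers stand for stronger inhibition of growth and higher numbers for weaker inhibition of growth), compound 1 `Cc1nnc(-c2nn(-c3ccccc3)c(-c3ccccc3)c2C#N)c2cn(-c3ccccc3)nc12` gives > 100000 nM, which is a limit of the assay and not a number. Compound 2 `N#Cc1c(-c2nnc(O)c3nn(-c4ccccc4)cc23)nn(-c2ccccc2)c1-c1ccccc1` gives 2760 nM. Compound 3 `N#Cc1c(-c2nnc(-c3nn(-c4ccccc4)c(-c4ccccc4)c3C#N)c3nn(-c4ccccc4)cc23)nn(-c2ccccc2)c1-c1ccccc1` gives 24500 nM, the higher of the two actual numbers in the series.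

Compound 4 `N#Cc1c(-c2nnc(-c3nn(-c4ccccc4)c(-c4ccccc4)c3C#N)c3nn(-c4ccc(Cl)cc4)cc23)nn(-c2ccccc2)c1-c1ccccc1` differs from compound 3 by chloro in place of hydrogen on an aromatic carbon: phenyl becomes 4-chlorophenyl, with the chloro para to a large group. Going by the values given here, only one measured step is available, namely an at least 36-fold lower number from compound 1 to compound 2 (1.55 log units; beyond the scatter). That step is large, but it is hydroxy in place of methyl, so it gives no direct measure of what chloro in place of hydrogen does. Among the compounds with values here, with no measured chloro step, no change beyond the scatter is expected in this assay, and the value of compound 3 at 24500 nM remains the best guide. The expected change is a 1.2-fold lower number from compound 3 to compound 4 (0.09 log units; within the scatter). For compound 4 the estimated value is 20000 nM, with an expected range from 6000 nM to 70000 nM.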

Compound 4, concentration for 50% growth inhibition: 7460 nM
Beside the measured number, compound 4's estimate is 2.7-fold (0.43 log units) above it, within the range that was stated.
By their numbers in this assay, from the lowest: compound 2; then compound 4; then compound 3. At a limit, above all of these: compound 1.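

Phenyl to 4-chlorophenyl, with the chloro para to a large group, brings a 3.3-fold lower number from compound 3 to compound 4 (0.52 log units; beyond the scatter) in this assay and so shows that this position responds to a single added atom. Going by these compounds alone, the only earlier step was hydroxy in place of methyl, so this is the first measured step that changes a phenyl group and leaves the rest of the compound as it was. Nothing measured here gives a reason for this step.

Going by these compounds, what a fluoro group, a methoxy group, an amine or a carboxylic acid would do at this same place stays open. On these data alone, it is also open whether chloro on a phenyl group of a smaller compound, such as compound 2, would give a step of similar size.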